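Methoxy in Place of Fluoro: From Compound 3 to Compound 4

The compounds below may be only part of what the source reports. "The series", "measured", "known", "first", "only" and "open" are said of these compounds alone.

Compound 1, `C=CC1=C(C(=O)Nc2ccc(OCC)cc2)C(c2ccc(OC)cc2)OC1`, gives > 100000 nM in a functional assay on QGY7701 cells (Homo sapiens) for cytotoxicity, read by MTT assay, with a stated time of 24 h (on this read-out lower numbers stand for stronger inhibition and higher numbers for weaker inhibition), a limit of the assay.
Compound 2, `C=CC1=C(C(=O)Nc2ccccc2)C(c2ccc(OC)cc2)OC1`, gives > 100000 nM in this assay, again a limit.
Compound 3, `C=CC1=C(C(=O)NCCCCC)C(c2ccc(F)cc2)OC1`, gives > 100000 nM in this assay, again a limit.

Compound 3 therefore stands at the limit of the assay, and it is not alone there: the limit of > 100000 nM in this assay, at which 3 of the 3 values shown sit, describes the whole set. Going by the values given here, the one step between measured compounds, a step that the two limits leave unreadable from compound 1 to compound 2, concerns the ethoxy group of compound 1 and is unreadable, so it carries no information on what follows.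

Compound 4, `C=CC1=C(C(=O)NCCCCC)C(c2ccc(OC)cc2)OC1`, differs from compound 3 by a single change, (methoxy in place of fluoro on an aromatic carbon). Among the compounds with values here, no measured step bears directly on this change. What the numbers do show is that compound 1 and compound 2, which both carry the methoxy group that enters in compound 4, sit at the limit, and that compound 3, which carries the fluoro group that leaves, sits at the limit as well. On this evidence the expected step that the limit leaves unreadable from compound 3 to compound 4 is none beyond the scatter, and compound 4 is expected to stay at the limit in this assay. The estimate for compound 4 is 150000 nM, with a range from 50000 nM to 500000 nM.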

Compound 4, half-maximal inhibitory concentration: > 100000 nM
Compound 4 gave a limit, no number (the forecaster's own chance of this, stated with the estimate: 85%); the middle value is on the limit's open side.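

In this assay compound 4 gives > 100000 nM, a limit of the assay. Going by these compounds alone, no step from compound 1, compound 2 or compound 3 to compound 4 can be read, and the whole set stands at a single value: the limit of > 100000 nM in this assay, at which 4 of the 4 values shown sit. The compounds shown leave open whether any of these changes alters cytotoxicity at all.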